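From Methyl to Chloro on the Benzyl Ring of Compound 1

This account rests on a few compounds, and the source may have more. Where it says the series, first, only, none or still open, it means among the compounds named here.

Measured compounds:
compound 1, `Cc1cccc(Cn2cc(COc3ccc4c(=O)ccoc4c3)nn2)c1`, > 100000 nM
compound 2, `Cc1ccccc1Cn1cc(COc2ccc3c(=O)ccoc3c2)nn1`, 15300 nM

In a functional assay on HeLa cells (Homo sapiens) for cytotoxicity, read by MTT assay, with a stated time of 48 h (on this read-out lower numbers stand for stronger inhibition and higher numbers for weaker inhibition), compound 1 gives only a limit, > 100000 nM, so it stands at the limit of > 100000 nM in this assay, at which 1 of the 2 values shown sits. Among the measured compounds shown here, compound 2 gives 15300 nM in this assay, and an at least 6.5-fold lower number from compound 1 to compound 2 (0.81 log units; beyond the scatter) is the only measured step in this set. Compound 3, `O=c1ccoc2cc(OCc3cn(Cc4cccc(Cl)c4)nn3)ccc12`, differs from compound 1 by chloro in place of methyl on an aromatic carbon. For the measured compounds named here, no measured step concerns this exchange of chloro for methyl; the step from compound 1 to compound 2 instead moved the methyl to another place. With compound 1 at a limit, the step of a number no higher from compound 1 to compound 3 (the limit leaves the size open) is expected to be no larger than the scatter. Compound 3 is therefore estimated at 100000 nM, between 30000 nM and 300000 nM.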

Compound 3, half-maximal inhibitory concentration: > 100000 nM
Compound 3 ended at the assay's limit; the forecaster's own chance of this, stated with the estimate: 55%; the middle value sits exactly at the limit.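

In this assay compound 3 gives a limit and not a number, and so joins compound 1: the limit of > 100000 nM in this assay, at which 2 of the 3 values shown sit.

Chloro in place of methyl, meta to a large group, thus brings no readable number, and the step between these two limits cannot be read. Only the 2-methylphenyl group gives a number, and it stands apart with an at least 6.5-fold higher number from compound 2 to compound 3 (0.81 log units; beyond the scatter).

Going by these compounds, what a 2-chlorophenyl group, or a methoxy or an amine on the same ring, would do in this assay stays open. On these data alone, whether the number for compound 2 belongs to the 2-methylphenyl group alone also stays open.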